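Methylsulfanyl replacing the pyridyl ester on an alpha-ketooxazole

The source may report more compounds than this note shows. Statements on the series, on what has been measured and on what is new or still open speak of the compounds shown alone.

Compound 1 `COC(=O)c1ccc(-c2cnc(C(=O)CCc3ccc(-c4ccccc4)cc3)o2)nc1` — 2.2 nM
Compound 2 `O=C(CCc1ccc(COc2ccccc2)cc1)c1ncc(I)o1` — 4 nM

Of the compounds shown here, two have been measured in an assay for inhibition of Fatty-acid amide hydrolase 1 (Rattus norvegicus); a lower number here means a stronger inhibitor, a higher number a weaker inhibitor. Compound 1 gives 2.2 nM, and compound 2 gives 4 nM. The gap between these two numbers lies within the usual scatter of this assay, so neither compound can be called the stronger inhibitor on these data alone.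

The unmeasured compound 3 `CSc1cnc(C(=O)CCc2ccc(-c3ccccc3)cc2)o1` follows from compound 1 by one change: methylsulfanyl in place of 5-(methoxycarbonyl)pyridin-2-yl on an aromatic carbon. Among the measured compounds shown here, no step of this kind between measured compounds is known here, so any expectation rests on the size of the group that leaves and the small group that enters. Compound 3 is expected to be a weaker inhibitor than compound 1, by a step of a 6.8-fold higher number from compound 1 to compound 3 (0.83 log units; beyond the scatter), somewhat beyond the scatter. In this assay compound 3 is estimated at 15 nM, with a likely range from 4 nM to 60 nM.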

Compound 3, inhibition constant: 3 nM
For compound 3 the middle estimate is 5.0-fold (0.70 log units) above the measured one; the measured number lies below the stated range.
By their numbers in this assay, from the lowest: compounds 1, 3 and 2 (each within the scatter of the next).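

In this assay, methylsulfanyl in place of 5-(methoxycarbonyl)pyridin-2-yl, on the aromatic carbon next to the ring oxygen, gives a 1.4-fold higher number from compound 1 to compound 3 (0.13 log units; within the scatter), so this pair shows neither a gain nor a loss. A group of 10 heavy atoms with a six-membered aromatic ring thus gives way to one of 2 heavy atoms with no ring, and for this pair, the larger group is not needed to keep a low number at this position. Nothing measured here accounts for this result.

The compounds shown leave open whether a plain hydrogen, a carboxylic acid or a dimethylamino group on this carbon would keep the number in the same range. They also leave open whether this exchange would give the same result with a different chain on the ketone.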